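A few compounds are considered here, and "the series" means these few. Any claim that something is new, unique, unknown or untested is made for them only; others in the source may bear on it.

Measured compounds:
- compound 1, `CC(C)(C)OC(=O)/N=C(\NC1=NC(=O)CN1C(C)(C)C)Nc1ccc(Cl)c(Cl)c1`, in an in vivo ADME assay on the whole organism for metabolic stability, with Mus musculus as the target, read by LC-MS, at a dose of 160 mg/kg by the oral route; on this read-out higher numbers stand for a longer-lived compound and lower numbers for a shorter-lived compound: < 0.167 h, a limit of the assay rather than a number.
- compound 2, `CC(C)N1CC(=O)N=C1N/C(=N\C(=O)OC(C)(C)C)Nc1ccc(Cl)c(Cl)c1`, in this assay: 0.263 h.

Among the measured compounds shown here, compound 2 holds the only numerical value shown; the other entry sits at the limit (the limit of < 0.167 h in this assay, at which 1 of the 2 values shown sits). Compound 3, `CN1CC(=O)N=C1N/C(=N\C(=O)OC(C)(C)C)Nc1ccc(Cl)c(Cl)c1`, is the next member, and it differs from compound 2 by methyl in place of isopropyl on an amine nitrogen in a ring. For the measured compounds named here, one measured step bears on this change, the shortening of the same alkyl group on the same ring nitrogen in an at least 1.5-fold higher number from compound 1 to compound 2 (0.19 log units; that floor lies within the scatter); that step cannot be sized beyond its floor, and the floor itself lies within the scatter. The present change shortens the group further, so for compound 3 no step beyond the scatter in this assay is expected, with a slight lean toward a higher number, as a 1.3-fold higher number from compound 2 to compound 3 (0.12 log units; within the scatter). Compound 3 is therefore expected to give 0.35 h, within 0.15 h to 0.8 h.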

Compound 3, half-life: < 0.167 h
Compound 3: a limit, no number; the forecaster's own chance of this, stated with the estimate: 20%; at least 2.0-fold (0.32 log units) between middle value and limit.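

In this assay, methyl in place of isopropyl on an amine nitrogen in a ring gives an at least 1.5-fold lower number from compound 2 to compound 3 (0.19 log units; that floor lies within the scatter). Among the compounds shown here, the rise suggested by the earlier step does not continue as the alkyl group on this nitrogen shortens, although neither step can be sized beyond a floor within the scatter: isopropyl in compound 2 is the only one of the three groups with a number, while tert-butyl in compound 1 and methyl in compound 3 both stand at a limit. The step between those two limit compounds cannot be read, so the picture at this position rests on one number and a shared limit: the limit of < 0.167 h in this assay, at which 2 of the 3 values shown sit.

Going by these compounds, how far compound 2 truly stands from compound 1 and compound 3 remains open. So does whether an ethyl group, a longer chain or a chain bearing an amine on this nitrogen would give a number in this assay.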